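The source may hold more compounds than are shown below. What is called first, only, known or untested is meant among the compounds shown, and "the series" means these compounds.

Measured in an ADME assay on HeLa cells (Homo sapiens) for cytotoxicity, read by resazurin assay, with a stated time of 65 h (a lower number here means that less compound is needed, a higher number that more compound is needed for the effect), both values being limits:
- compound 1 `CCc1cc(C(=O)OC)c(NC(=O)c2ccc([N+](=O)[O-])o2)s1`: > 20000 nM (a limit)
- compound 2 `CCCCOC(=O)c1cc(CC)sc1NC(=O)c1ccc([N+](=O)[O-])o1`: > 20000 nM (a limit)

Compound 2 stands at a limit and not at a number: the limit of > 20000 nM in this assay, at which 2 of the 2 values shown sit. Compound 3 `CCNC(=O)c1cc(CC)sc1NC(=O)c1ccc([N+](=O)[O-])o1` differs from compound 2 by ethylamino in place of butoxy on a carbonyl carbon. Going by the values given here, the only measured step, a step that the two limits leave unreadable from compound 1 to compound 2, has no size to carry over, so no step beyond the scatter is expected in this assay, and no direction. The expected step, a number no higher from compound 2 to compound 3 (the limit leaves the size open), is therefore only an estimate. Compound 3 is estimated at 20000 nM, with an expected range of 8000 nM to 40000 nM.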

Compound 3, half-maximal effective concentration: > 20000 nM
Compound 3 was reported as a limit; the forecaster's own chance of this, stated with the estimate: 75%; the middle value lies on the limit itself.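

In this assay, going by these compounds alone, compound 1, compound 2 and compound 3 all stand as limits, so no step among them can be read. The compounds shown leave open how far each lies from that limit, and whether ethylamino in place of butoxy changes the read-out at all.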